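A few compounds are considered here, and "the series" means these few. Any claim that something is new, unique, unknown or untested is made for them only; others in the source may bear on it.

Series on the shared core of compound 1 `CC(=O)Nc1cccc(S(=O)(=O)Oc2ccccc2C(C)C)c1`, tested in a functional assay on HT-29 cells (Homo sapiens) for antiproliferative activity, read by sulforhodamine B assay, with a stated time of 48 h; on this read-out higher numbers stand for weaker inhibition and lower numbers for stronger inhibition. Compound 1 gives 27000 nM. Compound 2 `CCCCCC(=O)Nc1cccc(S(=O)(=O)Oc2ccccc2C(C)C)c1` gives 19000 nM, and compound 3 `CC(C)C(=O)Nc1cccc(S(=O)(=O)Oc2ccccc2C(C)C)c1` gives 16000 nM; compound 3 has the lowest of the three numbers, but the three sit within the scatter of one another, as the steps show: a 1.4-fold lower number from compound 1 to compound 2 (0.15 log units; within the scatter), a 1.7-fold lower number from compound 1 to compound 3 (0.23 log units; within the scatter) and a 1.2-fold lower number from compound 2 to compound 3 (0.07 log units; within the scatter).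

Compound 4 `CC(C)c1ccccc1OS(=O)(=O)c1cccc(NC(=O)CCCl)c1` follows from compound 3 by 2-chloroethyl in place of isopropyl on a carbonyl carbon. Going by the values given here, the steps that bear on it are those that also alter the group on the carbonyl carbon, a 1.7-fold lower number from compound 1 to compound 3 (0.23 log units; within the scatter) and a 1.2-fold lower number from compound 2 to compound 3 (0.07 log units; within the scatter), both small. A step of similar size is therefore expected, no change at the digits printed from compound 3 to compound 4 (within the scatter), in no direction beyond the scatter. Compound 4 is estimated at 16000 nM, within 7000 nM to 36000 nM.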

Compound 4, half-maximal inhibitory concentration: 11000 nM
Compound 4: the middle estimate sits 1.5-fold (0.16 log units) above what was measured, within the range that was stated.
By their numbers in this assay, from the lowest: compounds 4, 3, 2 and 1 (each within the scatter of the next, the first and the last beyond it).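

Placing 2-chloroethyl on the carbonyl carbon in place of isopropyl leaves the number within the scatter (a 1.5-fold lower number from compound 3 to compound 4 (0.16 log units; within the scatter)), and the same holds against the pentyl chain (a 1.7-fold lower number from compound 2 to compound 4 (0.24 log units; within the scatter)). Against the methyl group, the chlorine-bearing chain gives the first step in the series beyond the scatter, though a modest one (a 2.5-fold lower number from compound 1 to compound 4 (0.39 log units; beyond the scatter)). No measurement on hand accounts for this step.

Whether chlorine itself matters stays open, since the compounds shown do not include a plain propyl chain. On these data alone, an amine or carboxylic acid at the chain end also remains untested here.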